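Swapping a Benzyl Group for a Methoxyphenyl Group

The compounds below may be only part of what the source reports. "The series", "measured", "known", "first", "only" and "open" are said of these compounds alone.

Compound 1, `Cc1ccccc1Nc1nc(Nc2ccccc2)ncc1Cl`: > 100000 nM
Compound 2, `CN1CCN(c2ccc(Nc3ncc(Cl)c(NCc4ccc(F)cc4)n3)nc2)CC1`: 19300 nM

Of the compounds shown here, two sharing a core have so far been tested in a functional assay on MCF7 cells (Homo sapiens) for inhibition, read by CCK-8 assay, with a stated time of 48 h; a lower number here means a stronger inhibitor of growth, a higher number a weaker inhibitor of growth. Compound 1 gives only a limit here, (the limit of > 100000 nM in this assay, at which 1 of the 2 values shown sits), so no number is known for it. Among the compounds with values here, compound 2 gives 19300 nM in this assay, the single plain number in the set, and so it stands alone as the only point of comparison. Within the data shown here, no pair of measured compounds differs in just one place, so no measured step is available to guide expectations.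

Compound 3, `COc1ccc(Nc2nc(Nc3ccc(N4CCN(C)CC4)cn3)ncc2Cl)cc1`, has not yet been measured in this assay. It differs from compound 2 by 4-methoxyphenyl in place of 4-fluorobenzyl on a nitrogen on an aromatic ring. Among the measured compounds shown here, with no measured step to lean on, the step of a 2.4-fold lower number from compound 2 to compound 3 (0.38 log units; beyond the scatter) is expected to be modest and toward stronger inhibition, though a step within the usual scatter is also quite possible. Compound 3 is therefore estimated at 8000 nM, with a range from 1500 nM to 40000 nM.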

Compound 3, concentration for 50% growth inhibition: 8450 nM
Estimate against measurement, compound 3: 1.1-fold (0.02 log units) below; the measured number falls inside the stated range.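

In this assay, within the data shown here, placing 4-methoxyphenyl instead of 4-fluorobenzyl on this nitrogen gives a 2.3-fold lower number from compound 2 to compound 3 (0.36 log units; beyond the scatter), the first measured step in the set, showing that growth inhibition at this position responds to the group attached and is not lost with this swap. The step combines more than one structural change: fluorine gives way to a methoxy group, which adds a hydrogen-bond acceptor, and the (4-fluorobenzyl)amino group becomes a (4-methoxyphenyl)amino group, so the gain cannot be assigned to either change alone. Nothing measured here explains the step.

A 4-fluorophenyl or 4-methoxybenzyl group would separate these two changes, and neither is among the compounds shown. Going by these compounds, it also remains open how this position would respond to a ring carrying an amine or a carboxylic acid.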